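Chloro in place of cyano on a pyridine amide

The compounds below may be only part of what the source reports. "The series", "measured", "known", "first", "only" and "open" are said of these compounds alone.

Measured compounds:
Compound 1, `Cc1ccc(-c2cc3n(n2)CCCC3)nc1`: 3000 nM
Compound 2, `N#Cc1ccc(NC(=O)c2cc3n(n2)CCCC3)nc1`: 90 nM

In a functional assay on HEK293 cells for negative allosteric modulation of metabotropic glutamate receptor 5 (Rattus norvegicus), read by FLIPR and calcium flux, with a stated time of 170 s (a higher number here means a weaker inhibitor, a lower number a stronger inhibitor), compound 2 gives 90 nM, the lower of the two numbers, while compound 1 gives 3000 nM. Compound 3, `O=C(Nc1ccc(Cl)cn1)c1cc2n(n1)CCCC2`, has not been measured; the change is chloro in place of cyano on an aromatic carbon. Among the compounds with values here, no measured pair shows this swap, so a modest step toward a somewhat higher number is expected, around the edge of the scatter. Compound 3 is expected to give 200 nM in this assay, between 60 nM and 700 nM, a step of a 2.2-fold higher number from compound 2 to compound 3 (0.35 log units; beyond the scatter).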

Compound 3, half-maximal inhibitory concentration: 262 nM
Compound 3: middle estimate off by 1.3-fold (0.12 log units), on the low side, and the stated range covers the measured number.
By their numbers in this assay, from the lowest: compound 2; then compound 3; then compound 1.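

In this assay, putting chloro in place of cyano on the aromatic carbon para to a large group gives a 2.9-fold higher number from compound 2 to compound 3 (0.46 log units; beyond the scatter). This position therefore accepts a single chlorine atom in place of the nitrile with only a modest loss of inhibition, and the nitrile remains the better of the two groups here. Nothing measured here explains this difference.

As far as these compounds go, whether a methoxy group or an amine on this carbon would match compound 2 remains open. Two groups at one position cannot establish a trend.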